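A few compounds are considered here, and "the series" means these few. Any claim that something is new, unique, unknown or untested is made for them only; others in the source may bear on it.

Compound 1 `COc1ccc(C(=O)CSc2nc3[nH]c(=O)n(C)c(=O)c3[nH]2)cc1` and compound 2 `Cn1c(=O)[nH]c2nc(SCC(=O)c3ccc(Cl)cc3)[nH]c2c1=O` share one core and differ only on the aromatic ring: chloro in place of methoxy on an aromatic carbon. In a functional assay on HT-29 cells (Homo sapiens) for inhibition, read by MTT assay, with a stated time of 48 h (a higher number here means a weaker inhibitor, a lower number a stronger inhibitor), compound 1 gives 6700 nM, and compound 2 gives 7200 nM; the step is a 1.1-fold higher number from compound 1 to compound 2 (0.03 log units; within the scatter). Compound 3 `COc1ccc(/C(CSc2nc3c([nH]2)c(=O)n(C)c(=O)n3C)=N\O)cc1` carries a different core and a different linker; how its core differs from that of compound 1 is not broken down here. In this assay compound 3 gives 1700 nM, the lowest of the three numbers and beyond the scatter from both compound 1 and compound 2.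

Compound 4 `Cn1c(=O)c2[nH]c(SC/C(=N/O)c3ccc(Cl)cc3)nc2n(C)c1=O` stands to compound 3 as compound 2 stands to compound 1: chloro in place of methoxy on an aromatic carbon. The place of the change reads the same word for word in both pairs, so it is the same change, made twice among the compounds shown. What compound 4 gives in this assay is not yet known.

Going by the values given here, the expectation rests on the single measured instance of this change, which from compound 1 to compound 2 moved the number by a 1.1-fold higher number from compound 1 to compound 2 (0.03 log units; within the scatter). On the core of compound 3 the same change is expected to give a step of about a 1.1-fold higher number from compound 3 to compound 4 (0.05 log units; within the scatter). Compound 4 is accordingly expected near 1900 nM, within a range from 900 nM to 4000 nM. The main uncertainty is that the change has been measured only once, and on a different core.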

Compound 4, half-maximal inhibitory concentration: 1200 nM
For compound 4 the middle estimate is 1.6-fold (0.20 log units) above the measured one; the range from low to high includes it.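

Chloro in place of methoxy on an aromatic carbon gives, in this assay, a 1.4-fold lower number from compound 3 to compound 4 (0.15 log units; within the scatter), which stays within the scatter, as the earlier step on the other core did. Set side by side, the two steps do not differ: the same change on two cores in this assay, a 1.1-fold higher number (0.03 log units; within the scatter) from compound 1 to compound 2 and a 1.4-fold lower number (0.15 log units; within the scatter) from compound 3 to compound 4, 1.5-fold (0.18 log units) apart, within the scatter of two such steps. Going by these compounds alone, this shows that the swap from 4-methoxyphenyl to 4-chlorophenyl carries across these two cores without a step beyond the scatter; it does not show that the same would hold on any further core or in any other assay, and with only two pairs it cannot fix the size of the step more closely than the scatter allows.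

The compounds shown leave open whether another group at this place on the six-membered aromatic ring, such as an amine, a carboxylic acid or a trifluoromethyl group, would move the number beyond the scatter on either core. They also leave open how much of the gap between the two pairs belongs to the core and how much to the linker, as compound 1 and compound 3 differ in more than one place and no compound shown separates the two.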